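From Nitro to Benzyloxy on a Shared Core

The compounds below may be only part of what the source reports. "The series", "measured", "known", "first", "only" and "open" are said of these compounds alone.

In a functional assay on MCF7 cells (Homo sapiens) for antiproliferative activity, read by MTT assay, with a stated time of 48 h (a lower number here means a stronger inhibitor, a higher number a weaker inhibitor), compound 2 `CC(=O)N1N=C(c2ccc3ccccc3c2)OC1c1ccc([N+](=O)[O-])cc1` gives 7.59 ug/mL, level with compound 1 `COc1ccc(C2OC(c3ccc4ccccc4c3)=NN2C(C)=O)cc1` at 7.35 ug/mL. With only these two numbers, compound 2 sits at no real extreme. Compound 3 `CC(=O)N1N=C(c2ccc3ccccc3c2)OC1c1ccc(OCc2ccccc2)cc1` has not yet been measured. It carries benzyloxy in place of nitro on an aromatic carbon, para to a large group: benzyloxy in place of nitro on an aromatic carbon. Just one measured step bears on this change, a 1.0-fold higher number from compound 1 to compound 2 (0.01 log units; within the scatter), where nitro replaced methoxy at that same place. Within the data shown here, that swap left the number unmoved, but benzyloxy brings an added aromatic ring, and no measured compound tests such a group. A step beyond the scatter in this assay is therefore not expected, though confidence is modest. The expected change is a 1.1-fold lower number from compound 2 to compound 3 (0.02 log units; within the scatter). For compound 3 the estimated value is 7.2 ug/mL, with an expected range of 3 ug/mL to 17 ug/mL.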

Compound 3, half-maximal inhibitory concentration: 5.49 ug/mL
Compound 3: middle estimate off by 1.3-fold (0.12 log units), on the high side; measured number inside the range.
By their numbers in this assay, from the lowest: compounds 3, 1 and 2 (each within the scatter of the next).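

In this assay, benzyloxy in place of nitro gives a 1.4-fold lower number from compound 2 to compound 3 (0.14 log units; within the scatter), so this place can now be seen to take a group with a whole extra aromatic ring and still keep the number within the scatter. Read from the other side, phenyl in place of hydrogen on the saturated chain carbon bound to the oxygen gives a 1.3-fold lower number from compound 1 to compound 3 (0.13 log units; within the scatter), and this step also stays within the scatter. Nitro, methoxy and benzyloxy, on an aromatic carbon para to a large group, therefore all leave compound 1, compound 2 and compound 3 level, despite the clear difference in size among these groups.

As far as these compounds go, whether an amine, a carboxylic acid or a longer chain at this place would move the number beyond the scatter stays open. Nothing available explains why these three groups give such similar numbers.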